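The source may report more compounds than this note shows. Statements on the series, on what has been measured and on what is new or still open speak of the compounds shown alone.

Values in a functional assay on the whole organism for agonist activity, with Mus musculus as the target; on this read-out lower numbers stand for an effect already at smaller amounts and higher numbers for an effect only at larger amounts of compound:

- Compound 1 `COC(=O)N(C)CC#CCN(C)C`: 17.3 mg/kg
- Compound 2 `O=C1NCCN1CC#CCn1ccnc1`: > 100 mg/kg, a limit
- Compound 3 `Cc1cncn1CC#CCN1CCNC1=O`: > 100 mg/kg, a limit

Compound 3 has no exact number in this assay, only the limit > 100 mg/kg. It shares that position with compound 2: the limit of > 100 mg/kg in this assay, at which 2 of the 3 values shown sit. Only compound 1 has a true number, so the data show no exact potency for compound 3.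

Compound 4 `Cc1cncn1CC#CCN1CCN(C)C1=O` has methyl in place of hydrogen on an amide-type nitrogen in a ring. Going by the values given here, the only measured step that bears on this change is a step that the two limits leave unreadable from compound 2 to compound 3. It also adds a methyl, but on an aromatic carbon, and it gives no size to carry over. No clear gain or loss in this assay is therefore expected, and compound 4 will probably also report only a limit. The expected size of a step that the limit leaves unreadable from compound 3 to compound 4 is highly uncertain. For compound 4, the estimated value is 130 mg/kg, with an expected range from 50 mg/kg to 300 mg/kg.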

Compound 4, dose for half-maximal effect: 2.5 mg/kg
Compound 4: the middle estimate sits 52-fold (1.72 log units) above what was measured, and the stated range ends above it.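

In this assay, putting a methyl in place of the amide hydrogen on the ring nitrogen gives an at least 40-fold lower number from compound 3 to compound 4 (1.60 log units; beyond the scatter). Going by these compounds alone, this shows that this nitrogen is a sensitive position, where a single added carbon moves the dose far beyond the usual scatter, whereas the only earlier step, a methyl on an aromatic carbon, cannot be read. The start of the new step is a limit and not a number, so its true size could be larger than the printed one: the limit of > 100 mg/kg in this assay, at which 2 of the 4 values shown sit.

Going by these compounds, whether the methyl on this nitrogen would have a similar effect without the methyl on the aromatic carbon remains open. It is also unknown how far this position tolerates something larger, such as an ethyl group, a longer chain or a hydroxyethyl group.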